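Swapping the Aryl Group on Compound 2

This account rests on a few compounds, and the source may have more. Where it says the series, first, only, none or still open, it means among the compounds named here.

In a functional assay on HT-29 cells (Homo sapiens) for antiproliferative activity, read by sulforhodamine B assay, with a stated time of 48 h (on this read-out lower numbers stand for stronger inhibition and higher numbers for weaker inhibition), compound 1 (`CCCCN1CCN(c2ccc(S(=O)(=O)Oc3ccccc3OC)cc2)C1=O`) gives > 100000 nM as its result, and this is a limit of the assay, not a number. Going by the values given here, compound 2 (`CCCCN1CCN(c2ccc(S(=O)(=O)Oc3ccc(OC)c(OC)c3)cc2)C1=O`) reads 21000 nM in this assay and is the only compound so far with a true number. That leaves a single measured step to learn from. It places 3,4-dimethoxyphenyl in place of 2-methoxyphenyl on an oxygen, and it amounts to an at least 4.7-fold lower number from compound 1 to compound 2 (0.67 log units; beyond the scatter) in this pair. So in these two compounds the read-out responds to the group on that oxygen.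

Compound 3 (`CCCCN1CCN(c2ccc(S(=O)(=O)Oc3cc(Br)cc(Br)c3)cc2)C1=O`) changes the same place, the oxygen whose other neighbour is the sulfonyl sulfur: 3,5-dibromophenyl in place of 3,4-dimethoxyphenyl on an oxygen is the full difference. The measured step never involved 3,5-dibromophenyl, so it shows that this place can matter but gives no direction for the new group. No shift beyond the scatter is expected, and the estimated step is a 1.1-fold lower number from compound 2 to compound 3 (0.02 log units; within the scatter) with wide uncertainty both ways. For compound 3 the estimate in this assay is 20000 nM with 4000 nM to 90000 nM as the expected range.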

Compound 3, half-maximal inhibitory concentration: 43000 nM
Beside the measured number, compound 3's estimate is 2.2-fold (0.33 log units) below it; the measured number falls inside the stated range.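

With a third group on the oxygen whose other neighbours are the sulfonyl sulfur, this assay shows that 3,5-dibromophenyl does not simply match 3,4-dimethoxyphenyl: the exchange gives a 2.0-fold higher number from compound 2 to compound 3 (0.31 log units; beyond the scatter), a modest loss, yet compound 3 still gives a true number with a group that has no hydrogen-bond acceptors. Set against 2-methoxyphenyl, the same group gives an at least 2.3-fold lower number from compound 1 to compound 3 (0.36 log units; beyond the scatter), so the three groups now fall into an order at this place, with 3,4-dimethoxyphenyl giving the lowest number and 2-methoxyphenyl the highest reading. The true size of that last step stays unknown because the reading for compound 1 is a limit of the assay and not a number: the limit of > 100000 nM in this assay, at which 1 of the 3 values shown sits.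

From the compounds shown here alone, all three groups are phenyl rings carrying methoxy or bromine, so it remains open how an unsubstituted phenyl, or a phenyl ring bearing an amine or a carboxylic acid, would read on this oxygen. The rest of the core is the same in all three compounds, so the effect of a longer chain there is open as well.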